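This account rests on a few compounds, and the source may have more. Where it says the series, first, only, none or still open, it means among the compounds named here.

In a functional assay on L02 cells (Homo sapiens) for inhibition, read by Griess assay, with stated times of 1 h and 24 h (a higher number here means a weaker inhibitor, a lower number a stronger inhibitor), three compounds have been read so far. Compound 1 `CCCc1nn(C)c2c(NC(C)C)nc(/C=C/c3nc(C)c(C)nc3C)nc12` gives a measured 342000 nM. For compound 2 `COc1cc(/C=C/c2nc(O)nc(NC(C)C)n2)cc(OC)c1OC`, the assay returns only a limit, < 40000 nM. For compound 3 `CC(C)Nc1nc(/C=C/c2ccccc2)nc2ccsc12`, it also returns only a limit, > 1000000 nM, so compound 3 has no exact place on the scale.

Compound 4 `C(=C/c1nc(Nc2ccccc2)c2sccc2n1)\c1ccccc1` keeps the core of compound 3 and changes one group: phenyl in place of isopropyl on a nitrogen on an aromatic ring. No measured pair among these compounds shows what such an exchange does in this assay, so no firm direction can be drawn from the data. The expected step, a step that the limit leaves unreadable from compound 3 to compound 4, is estimated to stay within the usual scatter. That expectation has only the limit of compound 3 at > 1000000 nM to rest on, and the assay may again report only a limit. Compound 4 is expected at about 1200000 nM, with an estimated range from 300000 nM to 5000000 nM.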

Compound 4, half-maximal inhibitory concentration: > 1000000 nM
Compound 4 was reported as a limit (the forecaster's own chance of this, stated with the estimate: 50%); the middle value does not contradict the limit.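

In this assay compound 4 returns only a limit, > 1000000 nM. Compound 3 likewise returns only a limit, > 1000000 nM, so no step can be read between compound 3 and compound 4. The compounds shown leave open what phenyl in place of isopropyl on a nitrogen on an aromatic ring does in this assay.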